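Replacing the 4-methoxyphenyl arm: outlook for compound 4

A few compounds are considered here, and "the series" means these few. Any claim that something is new, unique, unknown or untested is made for them only; others in the source may bear on it.

Measured so far:
compound 1 `COc1ccc(-c2nc3cccc(-c4cc(OC)c(OC)c(OC)c4)c3o2)cc1` — 3500 nM
compound 2 `COc1cc(-c2cccc3nc(-c4ccc(F)cc4)oc23)cc(OC)c1OC` — 8700 nM
compound 3 `COc1cc(-c2cccc3nc(-c4cccc(C)c4)oc23)cc(OC)c1OC` — > 25000 nM, a limit

In a functional assay on NCI-H460 cells (Homo sapiens) for antiproliferative activity, read by MTT assay, with a stated time of 48 h (on this read-out lower numbers stand for stronger inhibition and higher numbers for weaker inhibition), compound 1 gives 3500 nM and stands lowest of the two numbers in hand; compound 2 gives 8700 nM. Compound 3 reaches only the limit (the limit of > 25000 nM in this assay, at which 1 of the 3 values shown sits), so no number is available for it.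

Both measured steps that leave compound 1 raise the number: a 2.5-fold higher number from compound 1 to compound 2 (0.40 log units; beyond the scatter), and an at least 7.1-fold higher number from compound 1 to compound 3 (0.85 log units; beyond the scatter). Between the two replacements, an at least 2.8-fold higher number from compound 2 to compound 3 (0.45 log units; beyond the scatter). Every change made to the 4-methoxyphenyl arm of compound 1 so far has cost activity in this assay.

Compound 4 `COc1cc(-c2cccc3nc(-c4cccs4)oc23)cc(OC)c1OC` takes the same arm in a new direction: thiophen-2-yl in place of 4-methoxyphenyl on an aromatic carbon. The change removes the 4-methoxyphenyl, as the steps to compound 2 and compound 3 did, and brings in a smaller ring. On the basis of those two steps a modest rise in the number is expected for compound 4, roughly a 2.6-fold higher number from compound 1 to compound 4 (0.41 log units; beyond the scatter), with a real chance that only the limit is reached.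

For compound 4 the estimate in this assay is 9000 nM, expected to lie between 3000 nM and 25000 nM.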

Compound 4, half-maximal inhibitory concentration: 1600 nM
The estimate for compound 4 lay 5.6-fold (0.75 log units) above the measured number, outside the stated range (below it).
By their numbers in this assay, from the lowest: compound 4; then compound 1; then compound 2. At a limit, above all of these: compound 3.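

In this assay, thiophen-2-yl is the only replacement of the 4-methoxyphenyl arm shown that lowers the number: a 2.2-fold lower number from compound 1 to compound 4 (0.34 log units; beyond the scatter). This aromatic carbon, next to the ring nitrogen and next to the ring oxygen, therefore does not depend on a six-membered aromatic ring of carbon only, and the five-membered arm also reads better than the other two replacements, with a 5.4-fold lower number from compound 2 to compound 4 (0.74 log units; beyond the scatter) and an at least 15-fold lower number from compound 3 to compound 4 (1.19 log units; beyond the scatter). The last of these steps rests on a limit and not a number for compound 3: the limit of > 25000 nM in this assay, at which 1 of the 4 values shown sits.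

As far as these compounds go, whether furan-2-yl or thiophen-3-yl would match thiophen-2-yl stays open, so the part played by the sulfur and its place in the ring cannot yet be told apart from that of ring size. Also open, from the compounds shown here alone, is how thiophen-2-yl carrying a small substituent, such as a methyl group or an amine, would read in this assay.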